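Fluoro on compound 2: working notes

The source may report more compounds than this note shows. Statements on the series, on what has been measured and on what is new or still open speak of the compounds shown alone.

Measured in an ADME assay on HUVEC cells (Homo sapiens) for inhibition, read by CCK-8 assay, with a stated time of 24 h, in the presence of a further agent that is not named here (on this read-out lower numbers stand for stronger inhibition and higher numbers for weaker inhibition), so far:
- compound 1 `O=C1Nc2ccccc2/C1=C/c1ccc(-c2cn(-c3ccc(Cl)cc3)nn2)cc1` gives 18200 nM
- compound 2 `N#Cc1ccc(-n2cc(-c3ccc(C=C4C(=O)Nc5ccccc54)cc3)nn2)cc1` gives > 20000 nM

Within the data shown here, compound 1 carries the only true number in the set. Compound 2 stands at the limit of > 20000 nM in this assay, at which 1 of the 2 values shown sits. Its entry is a limit of the assay and not a number, so any comparison with compound 2 has an open end.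

Compound 3 `N#Cc1ccc(-n2cc(-c3ccc(C=C4C(=O)Nc5ccc(F)cc54)cc3)nn2)cc1` differs from compound 2 in one place: fluoro in place of hydrogen on an aromatic carbon. Fluoro replaces hydrogen on an aromatic carbon, meta to a fused ring and para to a fused ring. Among the measured compounds shown here, no measured pair in the set shows what this change does, so the expectation is a cautious one. No step beyond the usual scatter is expected in this assay, and no direction is favoured. The expectation rests on the limit of compound 2 at > 20000 nM and leaves a report of only a limit well within reach. The expected change is a number no higher from compound 2 to compound 3 (the limit leaves the size open). The estimated value for compound 3 is 20000 nM, with an expected range from 9000 nM to 45000 nM.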

Compound 3, half-maximal inhibitory concentration: > 20000 nM
Compound 3 was reported as a limit (the forecaster's own chance of this, stated with the estimate: 60%); the middle value lies on the limit itself.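

Compound 2 and compound 3 both stand as limits in this assay and not as numbers, so no step can be read for fluoro in place of hydrogen on an aromatic carbon: the limit of > 20000 nM in this assay, at which 2 of the 3 values shown sit.

The compounds shown leave open whether this fluoro changes inhibition at all, and in which direction.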